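The source may hold more compounds than are shown below. What is called first, only, known or untested is meant among the compounds shown, and "the series" means these compounds.

Compound 1 `Cc1cc(C)cc(Cn2c(=O)ccn(C3C=CC(OC(=O)c4ccccc4)C3)c2=O)c1` gives 40000 nM in an ADME assay on CCRF-CEM cells (Homo sapiens) for cytotoxicity, with a stated time of 3 days; on this read-out higher numbers stand for lower toxicity in this test and lower numbers for higher toxicity in this test.
Compound 2 `O=C(OC1C=CC(n2ccc(=O)n(Cc3ccccc3)c2=O)C1)c1ccccc1` gives > 25000 nM in this assay, which is a limit of the assay rather than a number.

Compound 2 therefore stands only at the limit of > 25000 nM in this assay, at which 1 of the 2 values shown sits, and its cytotoxicity can be placed no more exactly than that. Going by the values given here, the one measured step, a step that the limit leaves unreadable from compound 1 to compound 2, is for the same reason unreadable, so it gives neither a direction nor a size for what swapping groups at this position does.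

Compound 3 `Cc1ccc(Cn2c(=O)ccn(C3C=CC(OC(=O)c4ccccc4)C3)c2=O)c(C)c1` differs from compound 2 by 2,4-dimethylphenyl in place of phenyl on a saturated chain carbon bound to an aromatic nitrogen. Among the compounds with values here, no measured step bears on this change in a readable way. Within the data shown here, what can be said is that both compounds measured so far show weak cytotoxicity in this assay, and compound 1, which also carries a dimethylphenyl group at this position, gives a number rather than a limit.

Compound 3 is therefore expected to sit in the same weak region, with an estimated step that the limit leaves unreadable from compound 2 to compound 3 that cannot be called a change beyond the scatter. The estimate for compound 3 is 40000 nM, within a range from 20000 nM to 80000 nM.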

Compound 3, half-maximal cytotoxic concentration: 31000 nM
Compound 3: the middle estimate sits 1.3-fold (0.11 log units) above what was measured; the range from low to high includes it.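

The new comparison is between the two dimethylphenyl compounds in this assay: a 1.3-fold lower number from compound 1 to compound 3 (0.11 log units; within the scatter). Having 2,4-dimethylphenyl in place of 3,5-dimethylphenyl on this saturated chain carbon bound to an aromatic nitrogen therefore changes nothing that this test can tell apart, so the two arrangements of the methyl groups cannot be separated here. Compound 2, which carries plain phenyl, gives > 25000 nM, a limit of the assay and not a number, and both steps involving it cannot be read, so whether adding methyl groups to the phenyl ring shifts the result stays unsettled because compound 2 is placed only by this limit: the limit of > 25000 nM in this assay, at which 1 of the 3 values shown sits.

All the compounds shown carry a ring of carbon only at this position, which leaves open what a ring bearing an amine or a carboxylic acid, or a longer chain in place of the single carbon of the benzyl group, would give in this assay. They also leave open how far the result depends on the rest of the shared core, which is the same in all of them.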